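Cytotoxicity Limits Across Four Closely Related Analogues

A few compounds are considered here, and "the series" means these few. Any claim that something is new, unique, unknown or untested is made for them only; others in the source may bear on it.

Compound 1 `N#Cc1ccccc1Cn1ccc2nc(-c3ccccc3)nc-2c1`: in an ADME assay on MDBK cells (Bos taurus) for cytotoxicity (on this read-out higher numbers stand for lower toxicity in this test and lower numbers for higher toxicity in this test), compound 1 gives > 100000 nM, which is a limit of the assay and not a number.
Compound 2 `N#Cc1ccc(Cn2ccc3nc(-c4ccccc4)nc-3c2)cc1`: compound 2 gives > 100000 nM, again only a limit.
Compound 3 `FC(F)(F)c1ccccc1Cn1ccc2nc(-c3ccccc3)nc-2c1`: compound 3 gives > 100000 nM, likewise a limit.

Every measured value thus sits at the limit of > 100000 nM in this assay, at which 3 of the 3 values shown sit. Compound 2 differs from compound 1 by 4-cyanophenyl in place of 2-cyanophenyl on a saturated chain carbon bound to an aromatic nitrogen. For this pair the step is a step that the two limits leave unreadable from compound 1 to compound 2. Compound 3 differs from compound 1 by trifluoromethyl in place of cyano on an aromatic carbon, and here too the step is a step that the two limits leave unreadable from compound 1 to compound 3. Compound 4 `FC(F)(F)c1ccc(Cn2ccc3nc(-c4ccccc4)nc-3c2)cc1` has not been measured; it differs from compound 2 by trifluoromethyl in place of cyano on an aromatic carbon. Within the data shown here, this is the same kind of change as the one from compound 1 to compound 3, but the place differs: in compound 3 the entering group sits ortho to a large group, in compound 4 para to a large group. Because all three measured values sit at the limit of > 100000 nM in this assay, at which 3 of the 3 values shown sit, the step in this assay is expected to be unreadable as well, which is a step that the limit leaves unreadable from compound 2 to compound 4. Compound 4 is therefore estimated at 150000 nM, most likely reported only as a limit, with a range from 100000 nM to 300000 nM.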

Compound 4, half-maximal cytotoxic concentration: 84000 nM
Beside the measured number, compound 4's estimate is 1.8-fold (0.25 log units) above it; the whole stated range lies above it.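

In this assay, trifluoromethyl in place of cyano, para to a large group, gives an at least 1.1-fold lower number from compound 2 to compound 4 (0.07 log units; that floor lies within the scatter), so this step shows no change that can be told from the usual scatter of the test. The other steps shown, including the same change made on compound 1 to give compound 3, cannot be read, because their values are limits and not numbers: the limit of > 100000 nM in this assay, at which 3 of the 4 values shown sit. The two versions of the change therefore cannot be set side by side, so the data neither show that its effect carries from one core to another nor show that it fails to.

Among these compounds, compound 4 gives 84000 nM, the only true number in this small set, and it remains open how far the read-out could move with other groups on the same aromatic carbon. An amine or a carboxylic acid there, or a longer chain in place of the short link to the shared core, could show whether this assay responds to changes at these places at all.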